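Chloro-to-methoxy swap on the benzyl arm of compound 1

A few compounds are considered here, and "the series" means these few. Any claim that something is new, unique, unknown or untested is made for them only; others in the source may bear on it.

Measured so far:
compound 1, `O=C(OCC1CCCN(CCCc2ccccc2)C1)c1ccccc1N1C(=O)CC(Cc2ccc(Cl)cc2)C1=O`: 14500 nM
compound 2, `O=C(OCC1CCN(C(=O)CCc2ccccc2)CC1)c1ccccc1-c1ccccc1`: 9400 nM

In an in vitro functional assay on HEK ts201 cells for antagonist activity at Neuronal acetylcholine receptor; alpha3/beta4 (Homo sapiens), read by fluorescence and calcium flux (on this read-out lower numbers stand for stronger inhibition and higher numbers for weaker inhibition), compound 1 gives 14500 nM, the higher of the two numbers recorded; compound 2, which differs from it in several places, gives 9400 nM, and the gap between the two lies within the scatter, so neither is to be called the weaker inhibitor.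

Compound 3, `COc1ccc(CC2CC(=O)N(c3ccccc3C(=O)OCC3CCCN(CCCc4ccccc4)C3)C2=O)cc1`, has not been measured. It differs from compound 1 by methoxy in place of chloro on an aromatic carbon. Going by the values given here, with no step between measured compounds to lean on, no shift beyond the scatter is expected, and the estimated step is a 1.0-fold higher number from compound 1 to compound 3 (0.01 log units; within the scatter). For compound 3 the expected value is 15000 nM, within 5000 nM to 45000 nM.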

Compound 3, half-maximal inhibitory concentration: 28800 nM
Compound 3: the middle estimate sits 1.9-fold (0.28 log units) below what was measured; measured number inside the range.
By their numbers in this assay, from the lowest: compounds 2, 1 and 3 (each within the scatter of the next, the first and the last beyond it).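

Methoxy in place of chloro on the 4-chlorobenzyl arm, para to a large group, gives the first step in the series that changes one place only, read in this assay: a 2.0-fold higher number from compound 1 to compound 3 (0.30 log units; within the scatter). At this aromatic carbon, then, a single chlorine can give way to methoxy, with its added hydrogen-bond acceptor, without a shift beyond the scatter. No supporting data bear on this result.

On these data alone, how an amine or a carboxylic acid on this aromatic carbon would read remains open. So does whether any group here moves the number beyond the scatter.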